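This account rests on a few compounds, and the source may have more. Where it says the series, first, only, none or still open, it means among the compounds named here.

The two compounds measured in an ADME assay on HepG2 cells (Homo sapiens) for cytotoxicity, read by MTT assay, with a stated time of 72 h (on this read-out higher numbers stand for lower toxicity in this test and lower numbers for higher toxicity in this test), set the frame. Compound 1 `CC1(c2ccc(-c3ccco3)cc2)CC(S(=O)(=O)c2ccc(F)cc2)=C(c2ccc(/C(N)=N\O)cc2)O1` gives 7010 nM in this assay, and compound 2 `CC1(Cc2ccccc2)CC(S(=O)(=O)c2c(F)cccc2F)=C(c2ccc(/C(N)=N\O)cc2)O1` gives 91400 nM in this assay; compound 1 stands at the lower of the two numbers, with compound 2 above it by a margin beyond the scatter. Compound 2 differs from compound 1 in more than one place, so its value serves only as a second point of reference, not as a measured step.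

Compound 3 `COc1cc(-c2ccc(C3(C)CC(S(=O)(=O)c4ccc(F)cc4)=C(c4ccc(/C(N)=N\O)cc4)O3)cc2)cc(OC)c1OC` is the compound now under consideration. It differs from compound 1 in one place: 3,4,5-trimethoxyphenyl in place of furan-2-yl on an aromatic carbon. The remainder of the shared core, the sulfonyl-bearing aryl group and the amidoxime-bearing aryl group are kept.

For the measured compounds named here, with no single-point step measured between any two compounds, the account rests on the one anchor value of compound 1. Compound 3 is expected to stay close to that anchor, with an estimate of 6000 nM in this assay. The step of a 1.2-fold lower number from compound 1 to compound 3 (0.07 log units; within the scatter) is thus expected to lie within the scatter, with a range of 1500 nM to 25000 nM for compound 3.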

Compound 3, half-maximal cytotoxic concentration: > 50000 nM
Compound 3: no number, only a limit; the forecaster's own chance of this, stated with the estimate: 5%; at least 8.3-fold (0.92 log units) between middle value and limit.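

At this position, on an aromatic carbon para to a large group, the compounds now provide a first measured step. In this assay, 3,4,5-trimethoxyphenyl in place of furan-2-yl gives an at least 7.1-fold higher number from compound 1 to compound 3 (0.85 log units; beyond the scatter), so the group held here matters to this read-out, and this change moves it towards lower toxicity in this test. Compound 3 gives only a limit of the assay, > 50000 nM, and not a number, so the step has a lower bound but no known upper end: the limit of > 50000 nM in this assay, at which 1 of the 3 values shown sits.

For the compounds shown here, the single pair does not separate the effect of the larger entering group, with its 12 heavy atoms against 5, from that of its three oxygen atoms, and the change swaps the ring type as well. Going by these compounds, it remains open what an unsubstituted phenyl or a phenyl with a single methoxy group would give at this place, and whether the step would carry over to a core bearing a different sulfonyl aryl group from that of compound 1.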